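The source may hold more compounds than are shown below. What is called first, only, known or untested is meant among the compounds shown, and "the series" means these compounds.

Of the compounds shown here, three have been measured so far in a functional assay on A549 cells (Homo sapiens) for antiproliferative activity, read by MTT assay, with a stated time of 72 h; on this read-out lower numbers stand for stronger inhibition and higher numbers for weaker inhibition. Compound 1 (`S=C(Sc1ccccc1)N1CCCCC1`) gives 7930 nM, compound 2 (`S=C(Sc1ccccc1)N1CCOCC1`) gives 2520 nM, and compound 3 (`Cc1ccc(SC(=S)N2CCN(C(=O)OC(C)(C)C)CC2)cc1`) gives 2110 nM. Compound 3 and compound 2 stand level within the scatter, while compound 1 has a higher number than compound 3, with a gap beyond the scatter.

Compound 4 (`CC(C)(C)OC(=O)N1CCN(C(=S)Sc2ccc(F)cc2)CC1`) has not yet been measured. It differs from compound 3 in one place: fluoro in place of methyl on an aromatic carbon. In words, this is fluoro in place of methyl on an aromatic carbon, so that 4-methylphenyl becomes 4-fluorophenyl.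

Among the measured compounds shown here, no measured pair differs in only one place, and this exchange has not been tested on any other member. For the measured compounds named here, the only direct anchor is compound 3 at 2110 nM. No step beyond the scatter is expected in this assay, in either direction, so the estimate stays close to that anchor. The estimated move is a 1.1-fold higher number from compound 3 to compound 4 (0.04 log units; within the scatter), which would remain within the scatter. Going by the values given here, the range is kept wide on the higher and the lower side, as the series offers no measured step to calibrate it. For compound 4 the expected value is 2300 nM, with an estimated range of 1000 nM to 5500 nM.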

Compound 4, half-maximal inhibitory concentration: 1560 nM
The estimate for compound 4 lay 1.5-fold (0.17 log units) above the measured number; measured number inside the range.
By their numbers in this assay, from the lowest: compounds 4, 3 and 2 (each within the scatter of the next); then compound 1.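

In this assay, the exchange of 4-methylphenyl for 4-fluorophenyl, on an aromatic carbon para to a large group, gives a 1.4-fold lower number from compound 3 to compound 4 (0.13 log units; within the scatter), so this exchange does not separate the pair beyond the scatter. Among the compounds shown here, this is the first measured step that differs in one place, and it gives the place on the aromatic ring its first calibration: with the rest of the structure held constant, methyl and fluoro read alike here. No measured evidence bears on this result, and the two compounds alone do not explain it.

Going by these compounds, with only methyl and fluoro compared at this place, it remains open whether a larger or differently built group, such as methoxy, a nitrile, an amine or a carboxylic acid, would produce a step beyond the scatter. On these data alone, it also remains open whether fluoro at this place would read the same on the core of compound 1 or compound 2, since neither of these forms a one-place pair with compound 3 or compound 4.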